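This account rests on a few compounds, and the source may have more. Where it says the series, first, only, none or still open, it means among the compounds named here.

Compound 1 `CCOC(=O)/C=C/c1ccncc1-c1ccc2ccccc2c1`: 102%
Compound 2 `COC(=O)CCc1ccncc1-c1ccc2ccccc2c1`: 98%

In an assay on a protein complex for inhibition of CDK8/Cyclin C (Homo sapiens), with a stated time of 1 h, tested at 10 uM (on this read-out lower numbers stand for less inhibition and higher numbers for more inhibition at the one concentration tested (going by the name of the read-out)), compound 2 gives 98% and stands alongside compound 1, since the step of a number 4 percentage points lower from compound 1 to compound 2 (within the scatter) lies within the scatter. Compound 3 `COC(=O)COc1ccncc1-c1ccc2ccccc2c1` differs from compound 2 by (methoxycarbonyl)methoxy in place of 2-(methoxycarbonyl)ethyl on an aromatic carbon. For the measured compounds named here, the one measured step that bears on this, a number 4 percentage points lower from compound 1 to compound 2 (within the scatter), also altered the chain on this aromatic carbon and stayed within the scatter, so the step of a number 3 percentage points lower from compound 2 to compound 3 (within the scatter) is expected to be none beyond the scatter. Compound 3 is therefore estimated to give 95%, within a range from 85% to 102%.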

Compound 3, a percentage reported as inhibition, at one concentration (the size of the read-out at that concentration, not a potency): 11%
The estimate for compound 3 lay 84 percentage points above the measured number, outside the stated range (below it).
By their numbers in this assay, from the lowest: compound 3; then compounds 2 and 1 (each within the scatter of the next).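

In this assay, the chain on this aromatic carbon, opposite the ring nitrogen, proved far less forgiving than the earlier pair suggested: (methoxycarbonyl)methoxy in place of 2-(methoxycarbonyl)ethyl gave a number 87 percentage points lower from compound 2 to compound 3 (beyond the scatter), although both chains have the same count of heavy atoms. Set against 2-(ethoxycarbonyl)ethenyl, the same chain gave a number 91 percentage points lower from compound 1 to compound 3 (beyond the scatter), so the read-out here follows the identity of the chain and not its size alone. Nothing at hand explains this drop. As far as these compounds go, it remains open whether the ether oxygen alone carries the loss, or whether the ester also contributes. A longer chain on that oxygen, or a carboxylic acid or an amide in place of the methyl ester, would bear on this.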